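Trimming Trifluoromethyl to Fluoro on the Aryl Ring

The source may hold more compounds than are shown below. What is called first, only, known or untested is meant among the compounds shown, and "the series" means these compounds.

Within the data shown here, compound 2 `CCOC(=O)c1c(-c2cccc(C(F)(F)F)c2)csc1N` gives 30% in an assay on isolated protein for inhibition of protein kinase C zeta type (Homo sapiens), with stated times of 1 h and 2.5 min, tested at 30 uM (a higher number here means more inhibition at the concentration tested (going by the name of the read-out), a lower number less inhibition), the lower of the two numbers so far; compound 1 `CCOC(=O)c1c(-c2cccc(OC)c2)csc1N` gives 82%. Compound 3 `CCOC(=O)c1c(-c2cccc(F)c2)csc1N` differs from compound 2 by fluoro in place of trifluoromethyl on an aromatic carbon. Among the measured compounds shown here, the only measured step touching this position is a number 52 percentage points lower from compound 1 to compound 2 (beyond the scatter), a large fall. Fluoro itself has not been measured at this position, so where it lands between the two known substituents is open. A step of a number 25 percentage points higher from compound 2 to compound 3 (beyond the scatter) is expected, recovering part of that loss. Compound 3 is estimated at 55%, with a range from 30% to 80%.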

Compound 3, a percentage reported as inhibition, at one concentration (the size of the read-out at that concentration, not a potency): 38%
Beside the measured number, compound 3's estimate is 17 percentage points above it, within the range that was stated.
By their numbers in this assay, from the lowest: compounds 2 and 3 (each within the scatter of the next); then compound 1.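

In this assay fluoro in place of trifluoromethyl gives a number 8 percentage points higher from compound 2 to compound 3 (within the scatter) so the two groups cannot be told apart at this place. Fluoro in place of methoxy gives a number 44 percentage points lower from compound 1 to compound 3 (beyond the scatter) so the loss seen with trifluoromethyl is not particular to that group, and methoxy stands alone among the three. No measurement on hand accounts for what sets methoxy apart. On these data alone, whether the higher number depends on the oxygen or on the methyl of methoxy stays open. So does whether a hydroxyl, an amine or the longer ethoxy would keep it.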